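This account rests on a few compounds, and the source may have more. Where it says the series, first, only, none or still open, it means among the compounds named here.

Measured so far in a functional assay on MCF7 cells (Homo sapiens) for cytotoxicity, read by MTT assay, with a stated time of 72 h; a lower number here means a stronger inhibitor, a higher number a weaker inhibitor:
compound 1, `CN1[C@@H]2c3[nH]c4ccccc4c3C[C@H]1[C@H](C#N)N1[C@@H](CN3C(=O)c4ccccc4C3=O)c3[nH]c4ccccc4c3C[C@@H]21`: 610 nM
compound 2, `CN1[C@@H]2c3[nH]c4ccccc4c3C[C@H]1[C@H](C#N)N1[C@@H](CNC(=O)c3cc4ccccc4o3)c3[nH]c4ccccc4c3C[C@@H]21`: 320 nM

For the measured compounds named here, compound 2 holds the lowest of the two numbers, though the only step, a 1.9-fold lower number from compound 1 to compound 2 (0.28 log units; within the scatter), lies within the scatter. Compound 3, `CN1[C@@H]2c3[nH]c4ccccc4c3C[C@H]1[C@H](C#N)N1[C@@H](CNC(=O)/C=C/c3ccccc3)c3[nH]c4ccccc4c3C[C@@H]21`, differs from compound 2 by 2-phenylethenyl in place of 1-benzofuran-2-yl on a carbonyl carbon. Going by the values given here, the one measured step touches the same chain-end region and was within the scatter, so the data give no sign that swapping the aromatic group on the carbonyl moves the number beyond the scatter either way. Compound 3 is therefore expected near 400 nM (range 150 nM to 1200 nM), an estimated step of a 1.3-fold higher number from compound 2 to compound 3 (0.10 log units; within the scatter).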

Compound 3, half-maximal inhibitory concentration: 7190 nM
Beside the measured number, compound 3's estimate is 18-fold (1.25 log units) below it; the whole stated range lies below it.
By their numbers in this assay, from the lowest: compounds 2 and 1 (each within the scatter of the next); then compound 3.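

In this assay, the group on the carbonyl carbon turns out to matter: 2-phenylethenyl in place of 1-benzofuran-2-yl gives a 22-fold higher number from compound 2 to compound 3 (1.35 log units; beyond the scatter). Compound 3 also stands well apart from the other compound, with a 12-fold higher number from compound 1 to compound 3 (1.07 log units; beyond the scatter), so this chain end is not indifferent to change, as the first step alone might have suggested. Nothing available here explains the jump. As far as these compounds go, it remains open whether a plain phenyl or a saturated 2-phenylethyl group on the carbonyl carbon would give a number closer to compound 2 or to compound 3.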